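Acyl variation on the shared core: extension toward phenethylcarbonyl

This account rests on a few compounds, and the source may have more. Where it says the series, first, only, none or still open, it means among the compounds named here.

Compound 1 `CC(=O)N(C)c1ccc2[nH]c(-c3n[nH]c4ccccc34)cc2n1` carries an acetyl group on the amide nitrogen of the shared core; in a functional assay on HL-60 cells (Homo sapiens) for antiproliferative activity, read by MTT assay, with a stated time of 72 h (on this read-out higher numbers stand for weaker inhibition and lower numbers for stronger inhibition), compound 1 gives 5110 nM. Compound 2 `CN(C(=O)C(C)(C)C)c1ccc2[nH]c(-c3n[nH]c4ccccc34)cc2n1` gives 4990 nM and compound 3 `CN(C(=O)c1ccccc1)c1ccc2[nH]c(-c3n[nH]c4ccccc34)cc2n1` gives 4850 nM, both within the scatter of compound 1: a 1.0-fold lower number from compound 1 to compound 2 (0.01 log units; within the scatter), a 1.1-fold lower number from compound 1 to compound 3 (0.02 log units; within the scatter), and a 1.0-fold lower number from compound 2 to compound 3 (0.01 log units; within the scatter). Swapping the group on the carbonyl carbon among methyl, tert-butyl and phenyl thus leaves this assay unmoved. Compound 4 `CN(C(=O)CCc1ccccc1)c1ccc2[nH]c(-c3n[nH]c4ccccc34)cc2n1` differs from compound 1 by benzyl in place of hydrogen on a saturated chain carbon bound to a carbonyl carbon. All three measured steps bear on this acyl change and were within the scatter, so no step beyond the scatter is expected in this assay. Compound 4 is estimated at 5000 nM, range 2500 nM to 10000 nM, an expected step of a 1.0-fold lower number from compound 1 to compound 4 (0.01 log units; within the scatter).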

Compound 4, half-maximal inhibitory concentration: 4730 nM
The estimate for compound 4 lay 1.1-fold (0.02 log units) above the measured number; the range from low to high includes it.
By their numbers in this assay, from the lowest: compounds 4, 3, 2 and 1 (each within the scatter of the next).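

Lengthening the group on the carbonyl carbon to phenethyl still gives no step beyond the scatter in this assay (against the earlier acyl groups: a 1.1-fold lower number from compound 1 to compound 4 (0.03 log units; within the scatter); a 1.1-fold lower number from compound 2 to compound 4 (0.02 log units; within the scatter); a 1.0-fold lower number from compound 3 to compound 4 (0.01 log units; within the scatter)). The flat response at this position therefore extends from methyl, tert-butyl and phenyl to phenethyl, with the aromatic ring now carried on a saturated chain. No measurement on hand accounts for this flat response.

On these data alone, whether an amine or a carboxylic acid at the end of this chain would shift the number remains open. So does whether a longer chain would stay within the scatter.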